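The source may report more compounds than this note shows. Statements on the series, on what has been measured and on what is new or still open speak of the compounds shown alone.

This study tracks how a series of compounds built on a shared core behave in a toxicity assay on NIH3T3 cells (Mus musculus) for cytotoxicity, read by resazurin assay; on this read-out higher numbers stand for an effect only at larger amounts of compound and lower numbers for an effect already at smaller amounts. Compound 1 `CN(C)c1ccc(NCc2cncn2Cc2ccc(-c3ccccc3)cc2)cc1-c1ccccc1` is the starting point. In this assay compound 1 gives > 1000 nM, which is a limit of the assay rather than a number (the limit of > 1000 nM in this assay, at which 1 of the 3 values shown sits). Compound 2 `COC(=O)c1ccc(NCc2cncn2Cc2ccc(N)cc2)cc1-c1ccccc1` belongs to the same series. In this assay compound 2 gives > 10000 nM, again a limit of the assay and not a number (the limit of > 10000 nM in this assay, at which 1 of the 3 values shown sits). Among the compounds with values here, compound 3 `COC(=O)c1ccc(NCc2cncn2Cc2ccccc2Cl)cc1-c1ccccc1` is the one member with a plain number: in this assay compound 3 gives 10000 nM. Within the data shown here, the only step between measured compounds that differ in a single place is a number no higher from compound 2 to compound 3 (the limit leaves the size open), and its size stays open. Among the measured compounds shown here, compound 1 therefore stands at a limit, and no measured step reaches it.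

Compound 4 `c1ccc(-c2ccc(Cn3cncc3CNc3ccc(-c4noc5ccccc45)c(-c4ccccc4)c3)cc2)cc1` is the compound not yet measured. It differs from compound 1 in one place: a group of 9 heavy atoms (7 carbon, 1 nitrogen, 1 oxygen; one five-membered aromatic ring with 2 hetero atoms, one six-membered aromatic ring of carbon only) in place of a group of 3 heavy atoms (2 carbon, 1 nitrogen; no ring), on an aromatic carbon. For the measured compounds named here, no measured step concerns this place or this kind of change, so the expectation can rest only on the whole set, in which every compound sits at a limit or at a weak number. For compound 4 a value close to the rest is expected, the step that the limit leaves unreadable from compound 1 to compound 4 being estimated as no change beyond the scatter. The estimate for compound 4 is 10000 nM, expected to lie between 3000 nM and 30000 nM.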

Compound 4, half-maximal effective concentration: > 10000 nM
Compound 4: no number, only a limit; the forecaster's own chance of this, stated with the estimate: 60%; the middle value lies on the limit itself.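

The step from compound 1 to compound 4 cannot be read: in this assay both compounds sit at limits of the assay, not at numbers. The compounds shown leave open where the true values of compound 1 and compound 4 lie, and whether replacing the dimethylamino group on that aromatic carbon changes the effect on these cells at all.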